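Swapping a Benzyl for an Aryl on an Inactive Core

A few compounds are considered here, and "the series" means these few. Any claim that something is new, unique, unknown or untested is made for them only; others in the source may bear on it.

Compound 1 `CCN1CCN(c2ccc(Nc3ncc(Cl)c(Nc4ccccc4C)n3)nc2)CC1`: > 100000 nM
Compound 2 `Cc1ccccc1Nc1nc(Nc2ccc(N3CCCCC3)cc2)ncc1Cl`: > 100000 nM
Compound 3 `CN1CCN(c2ccc(Nc3ncc(Cl)c(NCc4ccc(F)cc4)n3)nc2)CC1`: > 100000 nM

In a functional assay on Jurkat cells (Homo sapiens) for inhibition, read by CCK-8 assay, with a stated time of 48 h (on this read-out lower numbers stand for stronger inhibition of growth and higher numbers for weaker inhibition of growth), compound 1 gives > 100000 nM, which is a limit of the assay rather than a number. Compound 2 gives > 100000 nM, again only a limit. Compound 3 gives > 100000 nM, also a limit. Among the measured compounds shown here, compound 3 therefore stands at the limit of > 100000 nM in this assay, at which 3 of the 3 values shown sit, with no measured compound anywhere else. Compound 4 `COc1cccc(Nc2nc(Nc3ccc(N4CCN(C)CC4)cn3)ncc2Cl)c1` differs from compound 3 in one place: 3-methoxyphenyl in place of 4-fluorobenzyl on a nitrogen on an aromatic ring. For the measured compounds named here, no step between measured compounds exists here, so nothing measured tells how large such a change can be. The expected step is a number no higher from compound 3 to compound 4 (the limit leaves the size open), none beyond the scatter. Compound 4 is estimated at 100000 nM, within 30000 nM to 300000 nM, most likely reported once more as a limit.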

Compound 4, concentration for 50% growth inhibition: 15800 nM
Beside the measured number, compound 4's estimate is 6.3-fold (0.80 log units) above it; measured number below the stated range.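

In this assay, the nitrogen on the aromatic ring of the shared core proves to be a place where a change can move growth inhibition: 3-methoxyphenyl in place of 4-fluorobenzyl gives an at least 6.3-fold lower number from compound 3 to compound 4 (0.80 log units; beyond the scatter). Compound 4 is the only compound shown with a true number, and the others stay at a limit: the limit of > 100000 nM in this assay, at which 3 of the 4 values shown sit.

The compounds shown do not separate the methoxy group from the switch from benzyl to phenyl. Going by these compounds, whether a phenyl carrying an amine or a carboxylic acid instead of the methoxy group would lower the number further remains open.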